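The source may report more compounds than this note shows. Statements on the series, on what has been measured and on what is new or still open speak of the compounds shown alone.

Measured so far in a functional assay on OVCAR-4 cells (Homo sapiens) for inhibition, read by sulforhodamine B assay, with a stated time of 48 h; a higher number here means a weaker inhibitor of growth, a lower number a stronger inhibitor of growth:

- compound 1 `Nc1cc(N)c2nc(-c3ccccc3)c(NCc3ccc(Cl)c(Cl)c3)nc2c1` gives 11700 nM
- compound 2 `CCOC(=O)[C@H](CCC(=O)O)NC(=O)c1ccc(Sc2nc3cc(N)cc(N)c3nc2-c2ccccc2)cc1` gives 16600 nM
- compound 3 `Nc1cc(N)c2nc(-c3ccccc3)c(Sc3ccc(F)cc3)nc2c1` gives 22900 nM

Compound 3 carries the highest of the three numbers, but neither neighbour is separated from it beyond the scatter: compound 2 sits nearest and compound 1 furthest, both within the usual spread of repeat measurements. On these numbers the three compounds are indistinguishable in this assay.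

Compound 4 `Nc1cc(N)c2nc(-c3ccccc3)c(Sc3ccc(Cl)c(Cl)c3)nc2c1` is not yet measured. It differs from compound 3 in one place:

3,4-dichlorophenyl in place of 4-fluorophenyl on a sulfur

Going by the values given here, no step between measured compounds covers this change, so nothing shows what it does. Among the compounds with values here, the only related point is compound 1, which also carries two chlorines on its pendant ring and gives a number within the scatter of compound 3. The expectation for compound 4 is therefore a step from compound 3 that stays within the scatter, with no clear direction, and the estimate is a 1.4-fold lower number from compound 3 to compound 4 (0.16 log units; within the scatter). Compound 4 is expected to give about 16000 nM, with a range from 6000 nM to 45000 nM in this assay.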

Compound 4, concentration for 50% growth inhibition: 20000 nM
The estimate for compound 4 lay 1.3-fold (0.10 log units) below the measured number; the measured number falls inside the stated range.
By their numbers in this assay, from the lowest: compounds 1, 2, 4 and 3 (each within the scatter of the next).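

In this assay, going by these compounds alone, 3,4-dichlorophenyl in place of 4-fluorophenyl on a sulfur gives a 1.1-fold lower number from compound 3 to compound 4 (0.06 log units; within the scatter), the first direct reading of a change at this position. Within this pair, the pendant ring can therefore go from one fluorine to two chlorines with no change in the number that stands out from the scatter, so this substitution does not separate the two compounds in this assay. Nothing at hand bears on why the step is this small.

As far as these compounds go, both rings in this pair carry only halogens, so it remains open whether a carboxylic acid or an amine on the pendant ring would move the number beyond the scatter. From the compounds shown here alone, it is equally open whether replacing the phenyl ring on the sulfur with a short alkyl chain would do so.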